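The source may report more compounds than this note shows. Statements on the series, on what has been measured and on what is new or still open speak of the compounds shown alone.

Measured in a functional assay (Superior cervical ganglion) with Rattus norvegicus as the target; a higher number here means a more potent compound, by a factor of ten per unit of this negative logarithm, a lower number a less potent compound:
- compound 1 `COC(=O)C1CC2CC1N(C)C2`: 5
- compound 2 `COC(=O)[C@@H]1C[C@@H]2C[C@H]1N(C)C2`: 4.4
- compound 3 `COC(=O)C1CC2CNC1C2`: 6.3

Compound 3 stands highest of these three, and its steps to both others lie beyond the scatter. Compound 1 is the nearer of the two, and compound 2 is the furthest away.

The next compound, compound 4 `COC(=O)[C@@H]1C[C@H]2CN[C@@H]1C2`, keeps the constitution of compound 3: the two compounds have the same atoms and bonds; at least one stereo element is drawn with a configuration in one of them and without one in the other: 3 of 3 stereo elements differ; a stereocentre at a saturated ring carbon is drawn without a configuration in compound 3 and R in compound 4; a stereocentre at a saturated ring carbon is drawn without a configuration in compound 3 and R in compound 4; a stereocentre at a saturated ring carbon is drawn without a configuration in compound 3 and R in compound 4. Its value in this assay has not yet been measured.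

Of the two measured steps, one is a direct precedent. The modest step of a number 0.60 log units lower from compound 1 to compound 2 (beyond the scatter) goes with the fact that one of compounds 1 and 2 is drawn with a defined configuration and the other without, at the place where they differ, and there too three stereocentres at saturated ring carbons pass from no drawn configuration to R. The large step of a number 1.30 log units higher from compound 1 to compound 3 (beyond the scatter), hydrogen in place of methyl on an amine nitrogen in a ring, involves a change that does not recur here. It only sets the higher level from which compound 4 starts.

One precedent is thin support, so the size of the change remains uncertain, but a modest fall is expected rather than a rise. The expected change is a number 0.60 log units lower from compound 3 to compound 4 (beyond the scatter). For compound 4 the estimated value is 5.7, with an expected range from 5 to 6.3.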

Compound 4, negative logarithm of the half-maximal effective concentration: 6.7
Compound 4: middle estimate off by 1.00 log units, on the low side; measured number outside the range, above it.
By their numbers in this assay, from the lowest: compound 2; then compound 1; then compound 3; then compound 4.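

In this assay, the change in drawn configuration no longer points one way: a number 0.40 log units higher from compound 3 to compound 4 (beyond the scatter), whereas a number 0.60 log units lower from compound 1 to compound 2 (beyond the scatter), so the fall seen with the methyl on the nitrogen does not carry over to the core with hydrogen there: the fact that one of compounds 3 and 4 is drawn with a defined configuration and the other without, at the place where they differ

The change of hydrogen in place of methyl on an amine nitrogen in a ring also proves larger among the compounds drawn with R centres, a number 2.30 log units higher from compound 2 to compound 4 (beyond the scatter), and its size depends on the core that carries it: the same change on two cores in this assay, a number 1.30 log units higher (beyond the scatter) from compound 1 to compound 3 and a number 2.30 log units higher (beyond the scatter) from compound 2 to compound 4, 1.00 log units apart, beyond the scatter of two such steps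

Read together, these steps show that within these four compounds the stereo change and the change on the nitrogen do not simply add up, so neither can be read without the other.

What the compounds shown leave open is how each of the three stereocentres contributes on its own, and what a centre drawn S would give. They also leave open whether a longer chain such as ethyl on the ring nitrogen, or a carboxylic acid or an amide in place of the methyl ester, would hold the level of compound 4.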